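The source may report more compounds than this note shows. Statements on the series, on what has been measured and on what is new or still open speak of the compounds shown alone.

For the measured compounds named here, in a functional assay on OCI-Ly3 cells (Homo sapiens) for inhibition, read by CellTiter-Glo, with stated times of 48 h and 96 h (on this read-out lower numbers stand for stronger inhibition of growth and higher numbers for weaker inhibition of growth), compound 1 `CC(C)[C@H](NC(=O)OCc1ccccc1)C(=O)N1CCC[C@H]1C(=O)N(C)[C@@H](CCCNC(=N)N)C(=O)CF` has the entry "not determined" (no result reported), so only two numbers can be compared. Compound 2 `CC(C)[C@H](NC(=O)c1cccc(Br)c1)C(=O)N1CCC[C@H]1C(=O)N[C@@H](CCCNC(=N)N)C(=O)CF` gives 530 nM, and compound 3 `CC(C)[C@H](NC(=O)c1ccc(Br)cc1)C(=O)N1CCC[C@H]1C(=O)N[C@@H](CCCNC(=N)N)C(=O)CF` gives 130 nM, the lower of the two. Compound 4 `COc1ccc(C(=O)N[C@H](C(=O)N2CCC[C@H]2C(=O)N[C@@H](CCCNC(=N)N)C(=O)CF)C(C)C)cc1` differs from compound 3 at one place: methoxy in place of bromo on an aromatic carbon. Going by the values given here, the only measured step, a 4.1-fold lower number from compound 2 to compound 3 (0.61 log units; beyond the scatter), moves the bromo rather than replacing it, so it bears only indirectly. It does show that a change on this aromatic group can matter. Among the compounds with values here, no measured step replaces bromo, so the direction remains uncertain. The expected step is a 1.5-fold higher number from compound 3 to compound 4 (0.19 log units; within the scatter), smaller than the measured one. For compound 4, the estimated value is 200 nM, with an expected range of 70 nM to 600 nM.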

Compound 4, concentration for 50% growth inhibition: 1670 nM
Compound 4: the middle estimate sits 8.4-fold (0.92 log units) below what was measured; the whole stated range lies below it.
By their numbers in this assay, from the lowest: compound 3; then compound 2; then compound 4.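

In this assay the replacement of bromo by methoxy at this place gives a 13-fold higher number from compound 3 to compound 4 (1.11 log units; beyond the scatter) and so shows that the group itself matters, not only where it sits. The place alone does not secure a low number: 4-methoxyphenyl in place of 3-bromophenyl gives a 3.2-fold higher number from compound 2 to compound 4 (0.50 log units; beyond the scatter) and so leaves compound 4 with the highest number of the three. No measurement shown here explains why methoxy does so much worse than bromo. Still open, on these data alone, is how an amine, a nitrile or a chloro group would read at this place. Also open, as far as these compounds go, is whether methoxy would fare differently on the neighbouring carbon that held bromo in compound 2.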